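Solubility of compounds 1 and 2, outlook for compound 3

A few compounds are considered here, and "the series" means these few. Any claim that something is new, unique, unknown or untested is made for them only; others in the source may bear on it.

Measured in a physicochemical assay for solubility, with a stated time of 18 h, at pH 7.4; on this read-out higher numbers stand for higher solubility and lower numbers for lower solubility:
- Compound 1 `COc1ccc(F)cc1CNCCCNc1ccnc2cc(Oc3ccc(F)cc3)ccc12`: 14500 nM
- Compound 2 `COc1ccc(F)cc1CNCCCNc1ccnc2cc(Oc3cccc(N(C)C)c3)ccc12`: 14500 nM

Level with compound 1, compound 2 stands at 14500 nM. Compound 3 `COc1ccc(F)cc1CNCCCNc1ccnc2cc(Cc3cccc(C(F)(F)F)c3)ccc12` carries 3-(trifluoromethyl)benzyl in place of 3-(dimethylamino)phenoxy on an aromatic carbon. Among the measured compounds shown here, the only measured step bearing on this is no change at the digits printed from compound 1 to compound 2 (within the scatter). For the measured compounds named here, that step exchanged one group on the oxygen for another, and no measurement yet covers a benzyl group, so the guidance is thin. Resting on it, no shift beyond the scatter is expected in this assay. The step expected is a 1.3-fold lower number from compound 2 to compound 3 (0.12 log units; within the scatter). For compound 3 the estimated value is 11000 nM, with an expected range of 4500 nM to 20000 nM.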

Compound 3, solubility: 4200 nM
The estimate for compound 3 lay 2.6-fold (0.42 log units) above the measured number; the measured number lies below the stated range.
By their numbers in this assay, from the lowest: compound 3; then compounds 1 and 2 (each within the scatter of the next).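

On this aromatic carbon of the core, the number in this assay does move with the group: 3-(trifluoromethyl)benzyl gives a 3.5-fold lower number from compound 2 to compound 3 (0.54 log units; beyond the scatter) and, in place of 4-fluorophenoxy, a 3.5-fold lower number from compound 1 to compound 3 (0.54 log units; beyond the scatter). The position is therefore not indifferent to every change, although the exchange between the two phenoxy groups showed no shift beyond the scatter. No data are available that bear on the origin of this step.

As far as these compounds go, the change replaces the oxygen link with a carbon link and also changes the ring substituent, so the share of each remains open. 3-(Trifluoromethyl)phenoxy or 3-(dimethylamino)benzyl would separate the two.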